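From thiophen-3-yl to phenyl on a shared core

A few compounds are considered here, and "the series" means these few. Any claim that something is new, unique, unknown or untested is made for them only; others in the source may bear on it.

Measured compounds:
- compound 1 `CNc1ncnc2c1c(-c1ccco1)cn2[C@@H]1O[C@H](CO)[C@@H](O)[C@H]1O`: 620 nM
- compound 2 `CNc1ncnc2c1c(-c1ccsc1)cn2[C@@H]1O[C@H](CO)[C@@H](O)[C@H]1O`: > 20000 nM (a limit)

In a functional assay on HL-60 cells (Homo sapiens) for antiproliferative activity, read by XTT assay, with a stated time of 72 h (on this read-out lower numbers stand for stronger inhibition and higher numbers for weaker inhibition), compound 1 gives 620 nM. Compound 2 gives > 20000 nM, which is a limit of the assay and not a number. Compound 2 therefore stands at the limit of > 20000 nM in this assay, at which 1 of the 2 values shown sits, and no exact value places it.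

Compound 3 `CNc1ncnc2c1c(-c1ccccc1)cn2[C@@H]1O[C@H](CO)[C@@H](O)[C@H]1O` keeps the shared core and changes one group: phenyl in place of thiophen-3-yl on an aromatic carbon. Going by the values given here, only one measured step bears on this change, an at least 32-fold higher number from compound 1 to compound 2 (1.50 log units; beyond the scatter). That large step, beyond the scatter, shows that a swap of group on this aromatic carbon can move the read-out strongly, but it does not involve phenyl. Since the reference point is only a limit, the size of the coming step is uncertain. No step beyond the scatter towards stronger inhibition is expected, and weaker inhibition might not be resolved at all. The expected step is a number no higher from compound 2 to compound 3 (the limit leaves the size open). For compound 3 the estimated value is 20000 nM, with an expected range from 4000 nM to 40000 nM.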

Compound 3, half-maximal inhibitory concentration: > 20000 nM
Compound 3: no number, only a limit; the forecaster's own chance of this, stated with the estimate: 65%; the middle value sits exactly at the limit.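

In this assay, phenyl in place of furan-2-yl gives an at least 32-fold higher number from compound 1 to compound 3 (1.50 log units; beyond the scatter), so at this aromatic carbon the large loss is no longer tied to thiophen-3-yl alone: a five-membered and a six-membered aromatic ring both fall far short of furan-2-yl. Compound 3 gives > 20000 nM in this assay, which is a limit of the assay, so the step from thiophen-3-yl to phenyl cannot be read and the two groups cannot be placed in any order. Of the three groups shown on this carbon, furan-2-yl alone gives a measured number, and the other two end at the same limit: the limit of > 20000 nM in this assay, at which 2 of the 3 values shown sit.

The compounds shown leave open whether the number of compound 1 depends on the furan ring itself or on how that ring is attached, which furan-3-yl or thiophen-2-yl on the same carbon would begin to address. They also leave open how this position responds to groups of a different kind, such as an amine or a short alkyl chain, and how far thiophen-3-yl and phenyl lie beyond the limit.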